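A Propyl-for-Fluorophenyl Swap Measured Once, Expected Again

A few compounds are considered here, and "the series" means these few. Any claim that something is new, unique, unknown or untested is made for them only; others in the source may bear on it.

The measured compounds are these. Compound 1, `COc1ccc([C@@H]2C/C(=N\O)c3c(O)cc(OCc4cn(Cc5ccccc5F)nn4)cc3O2)cc1O`, gives in a functional assay on RAW264.7 cells (Mus musculus) for inhibition, read by Griess assay, with stated times of 2 h and 24 h (on this read-out lower numbers stand for stronger inhibition and higher numbers for weaker inhibition), a value of 5710 nM. Compound 2, `CCCCn1cc(COc2cc(O)c3c(c2)O[C@H](c2ccc(OC)c(O)c2)C/C3=N\O)nn1`, gives in this assay a value of 8900 nM. Compound 3, `COc1ccc([C@@H]2CC(=O)c3c(O)cc(OCc4cn(Cc5ccccc5F)nn4)cc3O2)cc1O`, gives in this assay a value of 7320 nM.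

Among these three numbers compound 3 stands second highest. Its nearest neighbour is compound 2, whose number is a little higher, and its furthest is compound 1, whose number is a little lower; both gaps lie within the usual scatter, so the three compounds cannot be ordered by potency on this evidence.

Compound 4, `CCCCn1cc(COc2cc(O)c3c(c2)O[C@H](c2ccc(OC)c(O)c2)CC3=O)nn1`, has not yet been measured. It differs from compound 3 in one place: propyl in place of 2-fluorophenyl on a saturated chain carbon bound to an aromatic nitrogen. For the measured compounds named here, one measured step bears directly on this change. The same swap, on a closely related core, gave a 1.6-fold higher number from compound 1 to compound 2 (0.19 log units; within the scatter). That step stayed within the scatter, so the analogous step from compound 3 to compound 4 is expected to stay within the scatter as well, leaning if anything toward a slightly higher number: a 1.3-fold higher number from compound 3 to compound 4 (0.11 log units; within the scatter). Compound 4 is therefore estimated at 9500 nM, with a range from 5500 nM to 17000 nM.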

Compound 4, half-maximal inhibitory concentration: 13900 nM
Compound 4: middle estimate off by 1.5-fold (0.17 log units), on the low side, and the stated range covers the measured number.
By their numbers in this assay, from the lowest: compounds 1, 3, 2 and 4 (each within the scatter of the next, the first and the last beyond it).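

In this assay, the swap of 2-fluorophenyl for propyl, on a saturated chain carbon bound to an aromatic nitrogen, now has a second reading, a 1.9-fold higher number from compound 3 to compound 4 (0.28 log units; within the scatter), and like the first it stays within the scatter. The earlier compounds shown here could not show whether this change reads alike on more than one core, and the two readings now agree closely: the same change on two cores in this assay, a 1.6-fold higher number (0.19 log units; within the scatter) from compound 1 to compound 2 and a 1.9-fold higher number (0.28 log units; within the scatter) from compound 3 to compound 4, 1.2-fold (0.09 log units) apart, within the scatter of two such steps. Neither step on its own separates the two compounds it joins, but both run in the same direction, a consistency that rests on these two pairs alone.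

With only 2-fluorobenzyl and butyl compared at this place, the compounds shown leave open whether the numbers follow the ring, its fluorine or the chain. On these data alone, what an unsubstituted benzyl, a hexyl chain or a chain ending in a carboxylic acid would give here also remains open, as does whether the same direction would hold on any further core.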